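Swapping the ring substituent on compound 2: what to expect

A few compounds are considered here, and "the series" means these few. Any claim that something is new, unique, unknown or untested is made for them only; others in the source may bear on it.

Of the compounds shown here, three sharing one core have been tested in a functional assay on OVCAR-3 cells (Homo sapiens) for inhibition, read by MTT assay, with a stated time of 24 h; on this read-out higher numbers stand for weaker inhibition and lower numbers for stronger inhibition. Compound 1 `CC1(C)[C@H]2CC[C@]1(C)N(Cc1cn(-c3cccc(F)c3)nn1)C(=O)C2` gives 430 nM, compound 2 `CC1(C)[C@H]2CC[C@]1(C)N(Cc1cn(-c3cccc(C#N)c3)nn1)C(=O)C2` gives 230 nM, and compound 3 `Cc1ccc(-n2cc(CN3C(=O)C[C@@H]4CC[C@@]3(C)C4(C)C)nn2)cc1` gives 40 nM. Compound 2 sits second highest of the three; the gap a 1.9-fold lower number from compound 1 to compound 2 (0.27 log units; within the scatter) is within the scatter, whereas a 5.8-fold lower number from compound 2 to compound 3 (0.76 log units; beyond the scatter) and an 11-fold lower number from compound 1 to compound 3 (1.03 log units; beyond the scatter) are not. The unmeasured compound 4 `Cc1cccc(-n2cc(CN3C(=O)C[C@@H]4CC[C@@]3(C)C4(C)C)nn2)c1` differs from compound 2 by methyl in place of cyano on an aromatic carbon. For the measured compounds named here, no measured step changes only that group at that position. The estimate leans on the gain seen when the 4-methylphenyl entered in a 5.8-fold lower number from compound 2 to compound 3 (0.76 log units; beyond the scatter). The estimate is tempered: in compound 4 the methyl sits at a different position than in compound 3. Compound 4 is expected to give 120 nM, between 40 nM and 350 nM, a step of a 1.9-fold lower number from compound 2 to compound 4 (0.28 log units; within the scatter).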

Compound 4, half-maximal inhibitory concentration: 160 nM
Compound 4: middle estimate off by 1.3-fold (0.12 log units), on the low side, and the stated range covers the measured number.
By their numbers in this assay, from the lowest: compound 3; then compounds 4, 2 and 1 (each within the scatter of the next, the first and the last beyond it).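

Swapping cyano for methyl at this carbon leaves the number within the scatter (a 1.4-fold lower number from compound 2 to compound 4 (0.16 log units; within the scatter)), whereas methyl does separate from fluoro (a 2.7-fold lower number from compound 1 to compound 4 (0.43 log units; beyond the scatter)). Where the methyl sits matters more than the swap at this carbon: 3-methylphenyl in place of 4-methylphenyl costs clearly (a 4.0-fold higher number from compound 3 to compound 4 (0.60 log units; beyond the scatter)), so the low number of compound 3 does not carry over to compound 4. No measurement at hand explains these steps.

Open, as far as these compounds go, is whether the gain in compound 3 is specific to methyl or would also hold for an ethyl or a methoxy group in that place. Also open, from the compounds shown here alone, is how an amine or a carboxylic acid on this ring would read out.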